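Reversed Amide: Pyrazole Replaced by an Acetylphenyl Group

The source may report more compounds than this note shows. Statements on the series, on what has been measured and on what is new or still open speak of the compounds shown alone.

In a functional assay on LNCaP cells (Homo sapiens) for antiproliferative activity, read by CCK-8 assay, with a stated time of 6 days (on this read-out higher numbers stand for weaker inhibition and lower numbers for stronger inhibition), compound 1 `CC(=O)c1cc(C(=O)N[C@H](C)Cn2ccc(-c3cc(F)c(C#N)c(Cl)c3)n2)n[nH]1` gives 1080 nM and compound 2 `CC(O)c1cccc(C(=O)N[C@@H](C)Cn2ccc(-c3ccc(C#N)c(Cl)c3)n2)c1` gives 2280 nM. Compound 3 `CC(Cn1ccc(-c2ccc(C#N)c(Cl)c2)n1)C(=O)Nc1cc[nH]n1` carries the amide in the reversed sense, and in this assay compound 3 reaches only > 30000 nM, which is a limit of the measurement rather than a number, as noted in the limit of > 30000 nM in this assay, at which 1 of the 3 values shown sits. Compound 4 `CC(=O)c1cccc(NC(=O)C(C)Cn2ccc(-c3ccc(C#N)c(Cl)c3)n2)c1` keeps this reversed amide and differs from compound 3 in one place: 3-acetylphenyl in place of 1H-pyrazol-3-yl on an amide-type nitrogen. Within the data shown here, no measured pair shows such a change here, so the expectation rests on compound 3 alone. Compound 4 is expected to gain somewhat, by about an at least 2.0-fold lower number from compound 3 to compound 4 (0.30 log units; that floor lies within the scatter), though it may again fall at the limit. The estimate for compound 4 in this assay is 15000 nM, within 2000 nM to 30000 nM.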

Compound 4, half-maximal inhibitory concentration: 1540 nM
Estimate against measurement, compound 4: 9.7-fold (0.99 log units) above; measured number below the stated range.
By their numbers in this assay, from the lowest: compounds 1, 4 and 2 (each within the scatter of the next, the first and the last beyond it). At a limit, above all of these: compound 3.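

On the amide-type nitrogen of the reversed amide, the group carried there can decide whether this assay gives a measurable value at all: 3-acetylphenyl in place of 1H-pyrazol-3-yl brings an at least 19-fold lower number from compound 3 to compound 4 (1.28 log units; beyond the scatter). Compound 3 gives > 30000 nM, which is a limit and not a number, so this step is only a floor: the limit of > 30000 nM in this assay, at which 1 of the 4 values shown sits. The reversed amide alone therefore does not rule out activity on this read-out.

On these data alone, it stays open whether the six-membered aromatic ring or its acetyl group carries the gain. A plain phenyl group, or a phenyl group with an amine or a carboxylic acid in place of the acetyl, would separate the two.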